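Phenyl replaces isopropyl on an amide-type nitrogen

A few compounds are considered here, and "the series" means these few. Any claim that something is new, unique, unknown or untested is made for them only; others in the source may bear on it.

In an ADME assay on microsomes from liver (Homo sapiens) for metabolic stability, read by LC-MS, with NADPH named in the record, with a stated time of 60 min, tested at 1 uM, in the absence of a further agent (a lower number here means that less of the compound is left, a higher number that more of the compound is left), compound 2 `COc1ccc(-c2c(C)nc3c(N4CC[C@@H](NC(=O)NC(C)C)C4)cc(C)nn23)cc1OC` gives > 95%, which is a limit of the assay and not a number. Compound 1 `COc1ccc(-c2c(C)nc3c(N4CC[C@@H](NC(=O)c5ccccc5)C4)cc(C)nn23)cc1OC` gives > 95%, and this too is a limit. Going by the values given here, the only measured step is therefore a step that the two limits leave unreadable from compound 1 to compound 2, so it offers no size to carry forward. The two compounds share one feature: the limit of > 95% in this assay, at which 2 of the 2 values shown sit.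

Compound 3 `COc1ccc(-c2c(C)nc3c(N4CC[C@@H](NC(=O)Nc5ccccc5)C4)cc(C)nn23)cc1OC` carries a single change from compound 2: phenyl in place of isopropyl on an amide-type nitrogen. The closest guide is compound 1, which also holds a phenyl and gives > 95%, a limit. On that slim basis, the expected result is a number at least 3 percentage points lower from compound 2 to compound 3 (that floor lies within the scatter), a step no larger than the usual scatter, although a drop cannot be ruled out. For compound 3 the estimate is 92%, with an expected range from 75% to 100%.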

Compound 3, percent of the compound remaining: > 95%
Compound 3 gave a limit, no number; the forecaster's own chance of this, stated with the estimate: 55%; middle value at least 3 percentage points from the limit.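

No step among compound 1, compound 2 and compound 3 can be read, as all three share one feature: the limit of > 95% in this assay, at which 3 of the 3 values shown sit.

The compounds shown leave open whether these three truly differ in this assay, and which change in one place would leave less of a compound remaining.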